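The compounds below may be only part of what the source reports. "The series", "measured", "known", "first", "only" and "open" are said of these compounds alone.

In a functional assay on MGC-803 cells (Homo sapiens) for inhibition, read by CCK-8 assay, with a stated time of 48 h (a higher number here means a weaker inhibitor, a lower number a stronger inhibitor), the values are:
Compound 1 (`COc1ccc(CN(C(=O)CSC(=S)N2CCN(C(=O)OC(C)(C)C)CC2)c2cc(OC)c(OC)c(OC)c2)cc1OC`): > 20000 nM (a limit of the assay, not a number)
Compound 2 (`COc1ccc(CN(C(=O)CSC(=S)N2CCN(C(=O)OC(C)(C)C)CC2)c2cc(OC)c(OC)c(OC)c2)cc1F`): 4870 nM
Compound 3 (`COc1ccc(CN(C(=O)CSC(=S)N2CCN(C(=O)OC(C)(C)C)CC2)c2cc(OC)c(OC)c(OC)c2)cc1Br`): 3710 nM

Compound 3 cannot be separated from compound 2 (a 1.3-fold lower number from compound 2 to compound 3 (0.12 log units; within the scatter)). Compound 4 (`COc1ccc(CN(C(=O)CSC(=S)N2CCN(C(=O)OC(C)(C)C)CC2)c2cc(OC)c(OC)c(OC)c2)cc1C`) follows from compound 3 by one change (methyl in place of bromo on an aromatic carbon): methyl in place of bromo on an aromatic carbon. Two steps replacing methoxy lie beyond the scatter (an at least 4.1-fold lower number from compound 1 to compound 2 (0.61 log units; beyond the scatter); an at least 5.3-fold lower number from compound 1 to compound 3 (0.73 log units; beyond the scatter)). Among the compounds with values here, the one exchange of bromo for fluoro does not. Within the data shown here, no methyl compound has been measured, so no step beyond the scatter is expected in this assay, and the expected step is small (a 1.3-fold higher number from compound 3 to compound 4 (0.13 log units; within the scatter)). For compound 4 the estimate is (5000 nM), with the result expected between 2000 nM and 14000 nM on repeated measurement.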

Compound 4, half-maximal inhibitory concentration: > 20000 nM
Compound 4 ended at the assay's limit; the forecaster's own chance of this, stated with the estimate: 15%; at least 4.0-fold (0.60 log units) between middle value and limit.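

In this assay, the position ortho to a methoxy group does not tolerate every single-heavy-atom group: methyl fails to keep the activity of bromo, with an at least 5.3-fold higher number from compound 3 to compound 4 (0.73 log units; beyond the scatter), and also that of fluoro, with an at least 4.1-fold higher number from compound 2 to compound 4 (0.61 log units; beyond the scatter). The result for compound 4 is a limit of the assay, not a number: the limit of > 20000 nM in this assay, at which 2 of the 4 values shown sit. The step from compound 1 to compound 4 cannot be read, so methyl and methoxy cannot be ranked here.

As far as these compounds go, it remains open whether chloro, an amine or a carboxylic acid at this position would give a readable value, as fluoro and bromo do.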